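The source may hold more compounds than are shown below. What is called first, only, known or untested is meant among the compounds shown, and "the series" means these compounds.

Two compounds have been measured in a functional assay on HCT-116 cells (Homo sapiens) for antiproliferative activity, read by MTT assay, with a stated time of 24 h; a higher number here means a weaker inhibitor, a lower number a stronger inhibitor:
compound 1, `C=CCOc1ccc2c(=O)c(-c3cc(OC)c(OC)cc3OC)coc2c1`, gives 6600 nM;
compound 2, `COc1cc(OC)c(-c2coc3cc(OCc4ccc(F)cc4)ccc3c2=O)cc1OC`, gives 950 nM.

Among these two numbers compound 2 stands lowest; its only neighbour is compound 1, and the single measured step, a 6.9-fold lower number from compound 1 to compound 2 (0.84 log units; beyond the scatter), runs in favour of compound 2. Compound 3, `COc1cc(OC)c(-c2coc3cc(OCc4cccc(F)c4)ccc3c2=O)cc1OC`, is not yet measured. It differs from compound 2 in one place: 3-fluorophenyl in place of 4-fluorophenyl on a saturated chain carbon bound to an oxygen on an aromatic ring. For the measured compounds named here, no measured step matches this kind of change. Going by the values given here, the one step available, a 6.9-fold lower number from compound 1 to compound 2 (0.84 log units; beyond the scatter), swapped vinyl for a whole 4-fluorophenyl ring; moving the fluorine from one place on that ring to another is a far smaller alteration, and nothing measured here shows how such a move plays out. The expectation for compound 3 in this assay is therefore a step within the scatter, a 1.2-fold higher number from compound 2 to compound 3 (0.06 log units; within the scatter), with no firm direction. Compound 3 is estimated at 1100 nM, with a range from 400 nM to 3000 nM.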

Compound 3, half-maximal inhibitory concentration: 4920 nM
Compound 3: the middle estimate sits 4.5-fold (0.65 log units) below what was measured; measured number outside the range, above it.
By their numbers in this assay, from the lowest: compound 2; then compounds 3 and 1 (each within the scatter of the next).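

In this assay the place of the fluorine on the ring counts at this position: a 5.2-fold higher number from compound 2 to compound 3 (0.71 log units; beyond the scatter) comes with nothing more than 3-fluorophenyl in place of 4-fluorophenyl, the same atoms joined differently. With a 1.3-fold lower number from compound 1 to compound 3 (0.13 log units; within the scatter) the 3-fluorophenyl group stands within the scatter of vinyl, so among these compounds a fluorophenyl ring as such does not bring the lower number; only 4-fluorophenyl does. Nothing available explains this difference.

Still open, from the compounds shown here alone, is how a phenyl ring with no fluorine, or a 4-chlorophenyl or 4-methoxyphenyl group, would behave at this place, and so whether 4-fluorophenyl is a lone case or one of several good groups. Also open, going by these compounds, is what a longer chain, or a chain ending in an amine, would do here.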